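This account rests on a few compounds, and the source may have more. Where it says the series, first, only, none or still open, it means among the compounds named here.

Measured so far:
Compound 1 `CC(C)(C)c1ccc(/C(=C/C(=O)Nc2ccc3c(c2)OCCO3)c2ccncc2)cc1`: 44 nM
Compound 2 `CC(C)(C)c1ccc(C(=CC(=O)Nc2ccc3c(c2)OCCO3)c2ccc(C(C)(C)C)cc2)cc1`: 2700 nM
Compound 3 `CC(C)c1ccc(/C=C/C(=O)Nc2ccc3c(c2)OCCO3)cc1`: 55 nM

All three were tested in a functional assay on CHO cells for inhibition of transient receptor potential cation channel subfamily V member 1 (Homo sapiens); on this read-out lower numbers stand for stronger inhibition and higher numbers for weaker inhibition. Compound 3 stands at the second highest of the three numbers. Its nearest neighbour is compound 1, whose value lies within the usual scatter of repeated measurements, so the two cannot be told apart. Compound 2 lies far off with the highest number of the three, beyond the scatter.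

Compound 4 `O=C(/C=C/c1ccc(O)cc1)Nc1ccc2c(c1)OCCO2` has not yet been measured. It differs from compound 3 in one place: hydroxy in place of isopropyl on an aromatic carbon. Among the compounds with values here, no pair of measured compounds that differ in exactly one place is available, so this step has no direct precedent. Compounds 1 and 3 both carry a bulky alkyl group at this place and both give low numbers, although compound 2, which also carries such groups, shows that this alone does not guarantee a low number. Exchanging the alkyl group for a single oxygen is expected to weaken inhibition in this assay, with a step of a 22-fold higher number from compound 3 to compound 4 (1.34 log units; beyond the scatter) expected to lie beyond the scatter. Compound 4 is therefore estimated at 1200 nM, within a range from 250 nM to 6000 nM.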

Compound 4, half-maximal inhibitory concentration: > 4000 nM
Compound 4 gave a limit, no number (the forecaster's own chance of this, stated with the estimate: 25%); middle value at least 3.3-fold (0.52 log units) from the limit.
By their numbers in this assay, from the lowest: compounds 1 and 3 (each within the scatter of the next); then compound 2. At a limit, above all of these: compound 4.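

In this assay, within the data shown here, this is the first change at this place that can be read directly: hydroxy in place of isopropyl, on an aromatic carbon para to a large group, gives an at least 72-fold higher number from compound 3 to compound 4 (1.86 log units; beyond the scatter). Compound 4 gave a limit and not an exact number: the limit of > 4000 nM in this assay, at which 1 of the 4 values shown sits. Among these compounds, the earlier compounds suggested only loosely that a bulky alkyl group might matter here, whereas this pair shows that, on this core, hydroxy does not stand in for isopropyl, although the true size of the loss remains unknown.

The compounds shown cannot tell whether the loss comes from removing the isopropyl carbons or from bringing in the hydroxy with its hydrogen-bond donor and acceptor; a methoxy group, a chlorine atom or an ethyl group at the same place would help separate the two. From the compounds shown here alone, it also stays open whether the same exchange would cost as much on the cores of compound 1 and compound 2, which carry a further aromatic ring.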